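This account rests on a few compounds, and the source may have more. Where it says the series, first, only, none or still open, it means among the compounds named here.

Working notes on the series. The shared core is seen in compound 1 `CCCc1cc(NC)c2cc(NC(=O)/C=C/c3ccc(C(F)(F)F)cc3)ccc2n1`. In a functional assay on HEK293 cells for activation of melanin-concentrating hormone receptor 1 (Homo sapiens), read by inositol phosphate accumulation (on this read-out higher numbers stand for an effect only at larger amounts of compound and lower numbers for an effect already at smaller amounts), compound 1 gives 150 nM. Compound 2 `CCCc1cc(N)c2cc(NC(=O)/C=C/c3ccc(F)cc3)ccc2n1` gives 200 nM in this assay, and compound 3 `CC(C)c1cc(N)c2cc(NC(=O)/C=C/c3ccc(C(F)(F)F)cc3)ccc2n1` gives 160 nM. Compound 1 thus holds the lowest of the three numbers, but its gap to compound 3 and its gap to compound 2 both lie within the scatter, so nothing separates the three on this read-out. Among the compounds with values here, no two measured compounds differ in one place only, so no measured step is available to show how a single change moves this assay within this core.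

Compound 4 `CCCc1cc(N(C)C)c2cc(NC(=O)/C=C/c3ccc(C(F)(F)F)cc3)ccc2n1` differs from compound 1 by methyl in place of hydrogen on a nitrogen on an aromatic ring, the methylamino becoming dimethylamino. Within the data shown here, with no measured step of this kind to lean on, compound 4 is expected to stay close to compound 1, the step of a 1.7-fold higher number from compound 1 to compound 4 (0.22 log units; within the scatter) expected to be small, at most a slight rise in number near the edge of the scatter. Compound 4 is estimated at 250 nM, within a range from 90 nM to 700 nM.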

Compound 4, half-maximal effective concentration: 300 nM
Compound 4: middle estimate off by 1.2-fold (0.08 log units), on the low side; low and high end bracket the measured number.
By their numbers in this assay, from the lowest: compounds 1, 3, 2 and 4 (each within the scatter of the next).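

The step gives the series its first single-place comparison in this assay, where methyl in place of hydrogen on a nitrogen on an aromatic ring comes with a 2.0-fold higher number from compound 1 to compound 4 (0.30 log units; within the scatter) and so stays short of a separable change. On this read-out, the hydrogen of the methylamino group of compound 1 is therefore not shown to be required, since the dimethylamino group cannot be told apart from it. Nothing at hand speaks to why the step has this size.

Still open, going by these compounds, is how this nitrogen responds to an ethyl group, a longer chain or an acetyl group in place of methyl. Also open, on these data alone, is whether the same methyl step reads alike from the amino group of compound 3.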